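This account rests on a few compounds, and the source may have more. Where it says the series, first, only, none or still open, it means among the compounds named here.

Compound 1 `N#Cc1ccc(Nc2nc(Cc3c(F)cccc3F)cc(=O)[nH]2)cc1`: > 2500 nM (a limit)
Compound 2 `Cc1c(C(C)c2c(F)cccc2F)nc(Nc2ccc(C#N)cc2)[nH]c1=O`: 1060 nM

Going by the values given here, in an ADME assay on MT4 cells (Homo sapiens) for cytotoxicity, read by MTT assay (a lower number here means that less compound is tolerated, a higher number that more compound is tolerated), compound 2 gives 1060 nM, the only exact number so far. The result for compound 1 is a limit of the assay, > 2500 nM.

Compound 3 `Cc1c(Cc2c(F)cccc2F)nc(Nc2ccc(C#N)cc2)[nH]c1=O` has not yet been measured. It departs from compound 2 by hydrogen in place of methyl on a saturated chain carbon bound to two aromatic carbons, with hydrogen in place of methyl on a saturated chain carbon bound to two aromatic carbons. Among the compounds with values here, no measured step of this kind is available, so any forecast is tentative. A modest rise in the tolerated concentration is expected, around the edge of the usual scatter. That direction leans on compound 1, whose > 2500 nM is a limit. The expected change is a 1.9-fold higher number from compound 2 to compound 3 (0.28 log units; within the scatter). For compound 3 the estimated half-maximal cytotoxic concentration is 2000 nM, with an expected range of 800 nM to 5000 nM.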

Compound 3, half-maximal cytotoxic concentration: > 2830 nM
Compound 3 was reported as a limit; the forecaster's own chance of this, stated with the estimate: 45%; at least 1.4-fold (0.15 log units) between middle value and limit.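

Hydrogen in place of methyl on a saturated chain carbon bound to two aromatic carbons is the first change at this position that can be read: in this assay it gives an at least 2.6-fold higher number from compound 2 to compound 3 (0.42 log units; beyond the scatter). Compound 3 stands at a limit of the assay, so the full size of this step stays unknown: the limit of > 2830 nM in this assay, at which 1 of the 3 values shown sits. Compound 1 also stands at a limit, so its step to compound 3 cannot be read: the limit of > 2500 nM in this assay, at which 1 of the 3 values shown sits.

The compounds shown leave open what a group other than methyl, such as an ethyl chain or a hydroxyl group, would do on this chain carbon in this assay. Also open, on these data alone, is whether methyl on the aromatic carbon changes the tolerated concentration at all, and what an amine in place of the nitrile would do.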